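The source may report more compounds than this note shows. Statements on the series, on what has been measured and on what is new or still open speak of the compounds shown alone.

Measured so far, in an ADME assay on the whole organism (Rattus norvegicus) for pharmacokinetics, at a dose of 1 mg/kg by the intravenous route; on this read-out lower numbers stand for narrower distribution and higher numbers for wider distribution into tissues:
- compound 1 `COc1ccc(F)cc1-c1ccnc2[nH]c(C3=CCC(C(=O)O)CC3)cc12` gives 0.51 L/kg
- compound 2 `COc1ccc(F)cc1-c1ccnc2[nH]c(C3=CCC(N[C@@H](C(=O)O)C(C)C)CC3)cc12` gives 1 L/kg
- compound 3 `COc1ccc(F)cc1-c1c(F)cnc2[nH]c(C3=CCN([C@H]4CC[C@@H](C(=O)O)CC4)CC3)cc12` gives 2.6 L/kg

Compound 3 stands highest of the three, and its gaps to compound 2 and to compound 1 both lie beyond the scatter.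

The next compound is compound 4 `COc1ccc(F)cc1-c1c(F)cnc2[nH]c(C3=CCN([C@H]4CC[C@H](C(=O)O)CC4)CC3)cc12`, still to be measured in this assay. Its difference from compound 3 is the two compounds have the same atoms and bonds and differ only in configuration as drawn: 2 of 2 stereo elements differ (all stereocentres are inverted: mirror images); a stereocentre at a saturated ring carbon is drawn s in compound 3 and r in compound 4; a stereocentre at a saturated ring carbon is drawn s in compound 3 and r in compound 4. The atoms and bonds are therefore unchanged, and only the configuration as drawn differs, at the two saturated ring carbons.

Going by the values given here, only one measured step links two compounds that differ in one place: a 2.0-fold higher number from compound 1 to compound 2 (0.29 log units; within the scatter). It lies within the scatter and concerns a different change, (1-carboxy-2-methylpropyl)amino in place of carboxy on a saturated ring carbon. Among the compounds with values here, it offers no direct measure for an inversion, and the data hold no measured pair of stereoisomers.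

The expectation therefore stays anchored on compound 3 at 2.6 L/kg, with no step beyond the scatter expected in either direction. The expected change is a 1.1-fold lower number from compound 3 to compound 4 (0.03 log units; within the scatter), and this estimate carries little support from the data.

For compound 4 the estimated value is 2.4 L/kg, with an expected range from 1.1 L/kg to 5 L/kg.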

Compound 4, volume of distribution at steady state: 2.7 L/kg
Estimate against measurement, compound 4: 1.1-fold (0.05 log units) below; the measured number falls inside the stated range.
By their numbers in this assay, from the lowest: compounds 1 and 2 (each within the scatter of the next); then compounds 3 and 4 (each within the scatter of the next).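

In this assay, going by these compounds alone, the series now holds a measured pair of stereoisomers, which the earlier compounds did not offer, and inverting both saturated ring carbons as drawn gives a 1.0-fold higher number from compound 3 to compound 4 (0.02 log units; within the scatter). On this read-out, the drawn configuration at these two carbons therefore does not separate the pair, at least for this carboxylic acid-bearing ring on this core. The comparison carries no other structural change, and its reading as a test of configuration alone rests on one point: the fact that compounds 3 and 4 differ only in the configuration as drawn

The compounds shown leave open whether configuration at these two carbons stays equally without consequence on this read-out when the carboxylic acid gives way to a primary amide or an amine, or when a longer chain carries the acid on the same ring. Going by these compounds, how the fluorine that compounds 3 and 4 carry on the shared core bears on their values also stays open, as does whether this single pair speaks for any other stereoisomeric pair.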